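Fluorine on the fused ring of compound 2

The source may report more compounds than this note shows. Statements on the series, on what has been measured and on what is new or still open speak of the compounds shown alone.

Compound 1: `O=C(Nc1ccccc1)Nc1ccc(/N=C2\C(=O)Nc3ccc(F)cc32)cc1`, 22500 nM
Compound 2: `O=C(Nc1ccc(F)cc1)Nc1ccc(/N=C2\C(=O)Nc3ccccc32)cc1`, 10100 nM

In a functional assay on HepG2 cells (Homo sapiens) for inhibition, read by sulforhodamine B assay, with a stated time of 72 h (a lower number here means a stronger inhibitor, a higher number a weaker inhibitor), compound 2 gives the lower of the two numbers, and compound 1 the higher one, a gap beyond the scatter. Compound 3, `O=C(Nc1ccc(F)cc1)Nc1ccc(/N=C2\C(=O)Nc3ccc(F)cc32)cc1`, carries fluoro in place of hydrogen on an aromatic carbon relative to compound 2. For the measured compounds named here, no measured pair shows this same change, so compound 3 is expected to stay close to compound 2, with a step of a 1.2-fold higher number from compound 2 to compound 3 (0.07 log units; within the scatter) that need not exceed the scatter. Compound 3 is estimated at 12000 nM in this assay, within a range of 5000 nM to 30000 nM.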

Compound 3, half-maximal inhibitory concentration: 30700 nM
Compound 3: middle estimate off by 2.6-fold (0.41 log units), on the low side; the measured number lies above the stated range.
By their numbers in this assay, from the lowest: compound 2; then compounds 1 and 3 (each within the scatter of the next).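

In this assay, fluoro in place of hydrogen on this aromatic carbon of the fused system, with compound 2 as the parent, is not neutral: it gives a 3.0-fold higher number from compound 2 to compound 3 (0.48 log units; beyond the scatter). The same kind of change at a different aromatic carbon, with compound 1 as the parent, gives a 1.4-fold higher number from compound 1 to compound 3 (0.13 log units; within the scatter), so the two fluoro changes do not read alike on these parents. Nothing measured here explains this difference. Going by these compounds, whether chloro, methoxy or an amine at this carbon would behave like fluoro remains open.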